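A few compounds are considered here, and "the series" means these few. Any claim that something is new, unique, unknown or untested is made for them only; others in the source may bear on it.

In a functional assay on the whole organism (Tail, strain ICR) with Mus musculus as the target, in the tail flick test, with a stated time of 90 min, at a dose of 25 umol/kg by the oral route (a lower number here means a weaker effect, a higher number a stronger effect of the compound at the dose given), compound 2 `O=C(CN(c1nc(Cl)nc2[nH]cnc12)C1CC1)N[C@@H](CO)C(=O)O` gives 43.9%. Compound 3 `CSCC[C@H](NC(=O)CN(c1nc(Cl)nc2[nH]cnc12)C1CC1)C(=O)OCc1ccccc1` gives 44.6% and compound 1 `O=C(CN(c1nc(Cl)nc2[nH]cnc12)C1CC1)N[C@@H](CO)C(=O)OCc1ccccc1` gives 34.5%; each of these lies within the usual scatter of the value of compound 2, so compound 2 cannot be separated from either. Compound 4 `O=C(O)C[C@H](NC(=O)CN(c1nc(Cl)nc2[nH]cnc12)C1CC1)C(=O)O` is not yet measured. It differs from compound 2 in one place: carboxy in place of hydroxy on a saturated chain carbon, two bonds along the chain from an amide-type nitrogen and a carbonyl carbon. Within the data shown here, the one measured step at this same place is a number 10.1 percentage points higher from compound 1 to compound 3 (beyond the scatter), while a number 9.4 percentage points higher from compound 1 to compound 2 (within the scatter) concerns a different part of the molecule. Because a number 10.1 percentage points higher from compound 1 to compound 3 (beyond the scatter) was only modest and brought in a different group, the step of a number 1.1 percentage points higher from compound 2 to compound 4 (within the scatter) is expected to stay small, with no clear movement beyond the scatter. Compound 4 is therefore estimated at 45%, between 30% and 60%.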

Compound 4, a percentage reported as activity, at one dose (the size of the read-out at that dose, not a potency): 25.1%
Compound 4: middle estimate off by 19.9 percentage points, on the high side; measured number outside the range, below it.
By their numbers in this assay, from the lowest: compounds 4, 1, 2 and 3 (each within the scatter of the next, the first and the last beyond it).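

Hydroxy to carboxy at this saturated chain carbon gives a number 18.8 percentage points lower from compound 2 to compound 4 (beyond the scatter), so this position is sensitive to the group it carries. Among these compounds, the only earlier step here, a number 10.1 percentage points higher from compound 1 to compound 3 (beyond the scatter), ran the other way, with a different entering group on the benzyl ester, so the direction of change at this place is not fixed. Nothing shown here explains the fall.

Going by these compounds, an amine or a longer chain ending in a carboxylic acid at this place remains open. So does the question of whether a benzyl ester of compound 4 would follow the same trend.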